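Swapping Chloro for Fluoro on a Shared Amide Scaffold

This account rests on a few compounds, and the source may have more. Where it says the series, first, only, none or still open, it means among the compounds named here.

Compound 1 `O=C(Nc1ccc(Oc2ccnc3[nH]ccc23)cc1)c1cn(-c2ccc(F)cc2)c2ccccc2c1=O` was tested in a functional assay on MCF7 cells (Homo sapiens) for inhibition, read by MTT assay, with a stated time of 72 h (on this read-out lower numbers stand for stronger inhibition and higher numbers for weaker inhibition), where compound 1 gives 720 nM. Its partner compound 2 `O=C(Nc1ccc(Oc2ccnc3[nH]ccc23)cc1)c1cn(-c2ccc(Cl)cc2)c2ccccc2c1=O` differs in one place, described as chloro in place of fluoro on an aromatic carbon, and in this assay compound 2 gives 1590 nM, so that a 2.2-fold higher number from compound 1 to compound 2 (0.34 log units; beyond the scatter). Compound 3 `Cn1ccc2c(Oc3ccc(NC(=O)c4cn(-c5ccc(F)cc5)c5ccccc5c4=O)cc3F)ccnc21` carries a different core; the difference between the two cores of compound 1 and compound 3 is not broken down here, and in this assay compound 3 gives "not determined" (no result reported), so there is no single number for it. Compound 4 `Cn1ccc2c(Oc3ccc(NC(=O)c4cn(-c5ccc(Cl)cc5)c5ccccc5c4=O)cc3F)ccnc21` stands to compound 3 as compound 2 stands to compound 1, the change being (chloro in place of fluoro on an aromatic carbon), the same change at the same kind of place. Without a value for compound 3 the expectation for compound 4 rests on compound 1 at 720 nM and the step from compound 1 to compound 2. Compound 4 is therefore expected near 1800 nM, within 400 nM to 8000 nM.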

Compound 4, half-maximal inhibitory concentration: 2120 nM
For compound 4 the middle estimate is 1.2-fold (0.07 log units) below the measured one; the measured number falls inside the stated range.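

Compound 3 has no single number in this assay, so the step from compound 3 to compound 4 cannot be read. From the compounds shown here alone, whether 4-fluorophenyl to 4-chlorophenyl shifts the number on the core of compound 4 as it does on that of compound 1 stays open. No evidence on causes is available.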